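The source may report more compounds than this note shows. Statements on the series, on what has been measured and on what is new or still open speak of the compounds shown alone.

In a physicochemical assay for solubility, at pH 6.8 (on this read-out lower numbers stand for lower solubility and higher numbers for higher solubility), compound 2 (`CN1CCc2nc(C(=O)NC3CCN(C(=O)OC(C)(C)C)CC3NC(=O)c3cc4cc(Cl)ccc4[nH]3)sc2C1`) gives < 1 ug/mL, which is a limit of the assay and not a number. It therefore sits at the limit of < 1 ug/mL in this assay, at which 1 of the 2 values shown sits. Compound 1 (`CN1CCc2nc(C(=O)N[C@@H]3CN(CC(=O)O)CC[C@@H]3NC(=O)c3cc4cc(Cl)ccc4[nH]3)sc2C1`), the other measured compound, gives 723 ug/mL. The next compound, compound 3 (`CCOC(=O)N1CCC(NC(=O)c2nc3c(s2)CN(C)CC3)C(NC(=O)c2cc3cc(Cl)ccc3[nH]2)C1`), differs from compound 2 in one place: ethyl in place of tert-butyl on an oxygen next to a carbonyl group. This puts ethyl in place of tert-butyl on an oxygen next to a carbonyl group, turning tert-butoxycarbonyl into ethoxycarbonyl. For the measured compounds named here, no measured pair shows what this exchange does in this assay, so the expectation is only a small upward step, starting from compound 2 at the limit of < 1 ug/mL in this assay, at which 1 of the 2 values shown sits. The estimated change is an at least 2.0-fold higher number from compound 2 to compound 3 (0.30 log units; that floor lies within the scatter). The assay may again report only a limit. For compound 3, the expected value is 2 ug/mL, with an estimated range of 1 ug/mL to 10 ug/mL.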

Compound 3, solubility: 37 ug/mL
Compound 3: middle estimate off by 19-fold (1.27 log units), on the low side; the measured number lies above the stated range.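

In this assay, the exchange of tert-butyl for ethyl on an oxygen next to a carbonyl group gives an at least 37-fold higher number from compound 2 to compound 3 (1.56 log units; beyond the scatter), the first measured sign that the read-out responds to a change in this place. Compound 2 stands at a limit and not at a number: the limit of < 1 ug/mL in this assay, at which 1 of the 3 values shown sits. The step is therefore a floor on the size of the change, and that floor already lies beyond the scatter, with 2 heavy atoms entering where 4 leave.

This single pair changes chain size and branching together, so it cannot say which of them goes with the higher number. A methyl, a longer unbranched chain such as n-butyl, or an amine in the same place would show whether the trend extends beyond ethyl.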